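The source may report more compounds than this note shows. Statements on the series, on what has been measured and on what is new or still open speak of the compounds shown alone.

Of the compounds shown here, three built on one shared core have been measured in a functional assay for inhibition, with a stated time of 2 h, tested at 0.125 g/L; a lower number here means less inhibition, a higher number more inhibition at the concentration tested (going by the name of the read-out). Compound 1 `Cc1sc2c(Nc3cccnc3)cccc2c1C` gives 76.1%. Compound 2 `COc1ccc(Nc2cccc3c(C)c(C)sc23)cc1OC` gives 100%, and compound 3 `COc1ccc(Nc2cccc3c(C)c(C)sc23)cc1` gives 100%. Compound 2 thus stands level with compound 3, the two together forming the highest of the three numbers, while compound 1 lies further off, beyond the scatter. One measured step, no change at the digits printed from compound 2 to compound 3 (within the scatter), was hydrogen in place of methoxy on an aromatic carbon: taking away one of the two methoxy groups left the read-out unchanged.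

Compound 4 `COc1cccc(Nc2cccc3c(C)c(C)sc23)c1` has not yet been measured. It differs from compound 2 by hydrogen in place of methoxy on an aromatic carbon. Going by the values given here, the only step that bears on this change is the removal of the other methoxy group, and because no change at the digits printed from compound 2 to compound 3 (within the scatter) lay within the scatter, no step beyond the scatter is expected here either. Compound 4 is therefore estimated at 97%, within a range from 85% to 100%. The expected step is a number 3 percentage points lower from compound 2 to compound 4 (within the scatter).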

Compound 4, a percentage reported as inhibition, at one concentration (the size of the read-out at that concentration, not a potency): 82.6%
For compound 4 the middle estimate is 14.4 percentage points above the measured one; the whole stated range lies above it.
By their numbers in this assay, from the lowest: compounds 1 and 4 (each within the scatter of the next); then compounds 2 and 3 (each within the scatter of the next).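

Replacing methoxy with hydrogen has different outcomes at the two methoxy positions of compound 2. At this position, para to a large group and ortho to a methoxy group, the change gives a number 17.4 percentage points lower from compound 2 to compound 4 (beyond the scatter) in this assay while at the other position it gave no change at the digits printed from compound 2 to compound 3 (within the scatter) in the same assay. The two methoxy groups therefore cannot be treated as interchangeable here, although nothing shown explains the difference.

On these data alone, it remains open whether this position needs methoxy specifically or whether another group, such as a hydroxyl group, a chlorine atom or a longer ethoxy chain, would restore the read-out. Going by these compounds alone, only one position-specific comparison is available, so it is also unclear whether the same difference would appear on a core other than the shared one.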